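A Methoxy-to-Hydroxy Swap on a Pyrazole Series

This account rests on a few compounds, and the source may have more. Where it says the series, first, only, none or still open, it means among the compounds named here.

Three measured compounds share a pyrazole core carrying two aryl groups. Compound 1 `O=[N+]([O-])c1ccc(-c2cc(-c3ccccc3)n[nH]2)cc1` gives 7200 nM in a functional assay on OVCAR cells (Homo sapiens) for inhibition, read by MTT assay, with a stated time of 48 h; on this read-out lower numbers stand for stronger inhibition of growth and higher numbers for weaker inhibition of growth. Compound 2 `Oc1ccc(-c2cc(-c3ccc(C(F)(F)F)cc3)n[nH]2)cc1` gives 9200 nM in this assay. Compound 3 `COc1ccccc1-c1cc(-c2ccccc2-c2ccccc2)n[nH]1` gives 14200 nM in this assay, a number that sits within the usual scatter of both compound 2 and compound 1, so the three cannot be told apart with confidence.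

Compound 4 `Oc1ccccc1-c1cc(-c2ccccc2-c2ccccc2)n[nH]1` is not yet measured. It differs from compound 3 by hydrogen in place of methyl on an oxygen on an aromatic ring. Among the measured compounds shown here, no measured pair shows this exact change on this core, so no step size is known. Because compound 2 gives 9200 nM with a hydroxy group on a similar scaffold, the change from compound 3 to compound 4 is expected to be a 1.2-fold lower number from compound 3 to compound 4 (0.07 log units; within the scatter), not beyond the scatter. Compound 4 is estimated at 12000 nM, within a range of 5000 nM to 30000 nM.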

Compound 4, concentration for 50% growth inhibition: 5800 nM
Estimate against measurement, compound 4: 2.1-fold (0.32 log units) above; low and high end bracket the measured number.
By their numbers in this assay, from the lowest: compounds 4, 1, 2 and 3 (each within the scatter of the next, the first and the last beyond it).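

Methoxy to hydroxy on this aromatic ring gives the first comparison in the series that changes only one place: in this assay the swap brings a 2.4-fold lower number from compound 3 to compound 4 (0.39 log units; beyond the scatter) and this modest step lies beyond the usual scatter. Among the compounds shown here, the group on this oxygen therefore matters for growth inhibition, something the earlier compounds, which differ in several places, could not show.

From the compounds shown here alone, whether an amine or an ethoxy group at this place would take the number further in either direction stays open. No measurement shown explains the size of this step.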